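The source may hold more compounds than are shown below. What is called first, only, known or untested is meant among the compounds shown, and "the series" means these compounds.

Compound 3 `COc1cc(NC(=O)Nc2cc(Nc3ccc(Br)cc3OC)ncn2)cc(OC)c1` gives 20.1% in a functional assay on NCI-H1581 cells (Homo sapiens) for inhibition, read by MTT assay, with a stated time of 48 h, tested at 10 uM (on this read-out higher numbers stand for more inhibition at the one concentration tested (going by the name of the read-out) and lower numbers for less inhibition), the lowest of the three numbers shown, though within the scatter of compound 2. Compound 1 `COc1cc(NC(=O)Nc2cc(Nc3cccc(C(C)(C)C)c3)ncn2)cc(OC)c1` gives 35.1% and compound 2 `CCc1cccc(Nc2cc(NC(=O)Nc3cc(OC)cc(OC)c3)ncn2)c1` gives 27.7%. The step of a number 15 percentage points lower from compound 1 to compound 3 (beyond the scatter) lies beyond the scatter, while a number 7.6 percentage points lower from compound 2 to compound 3 (within the scatter) and a number 7.4 percentage points lower from compound 1 to compound 2 (within the scatter) do not. Compound 4 `COc1cc(NC(=O)Nc2cc(Nc3cc(C)cc(F)c3)ncn2)cc(OC)c1` carries 3-fluoro-5-methylphenyl in place of 4-bromo-2-methoxyphenyl on a nitrogen on an aromatic ring. Both earlier steps on this nitrogen put 4-bromo-2-methoxyphenyl in place of 3-(tert-butyl)phenyl or 3-ethylphenyl and moved the number down; returning to a ring of the 3-fluoro-5-methylphenyl kind is therefore expected to move it back up modestly, a number 7.9 percentage points higher from compound 3 to compound 4 (within the scatter). For compound 4 the estimated value is 28%, with a range of 15% to 42%.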

Compound 4, a percentage reported as inhibition, at one concentration (the size of the read-out at that concentration, not a potency): 28.3%
Compound 4: middle estimate off by 0.3 percentage points, on the low side; low and high end bracket the measured number.
By their numbers in this assay, from the lowest: compounds 3, 2, 4 and 1 (each within the scatter of the next, the first and the last beyond it).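

On the nitrogen on an aromatic ring, 3-fluoro-5-methylphenyl gives a number 8.2 percentage points higher from compound 3 to compound 4 (within the scatter) and a number 0.6 percentage points higher from compound 2 to compound 4 (within the scatter) and a number 6.8 percentage points lower from compound 1 to compound 4 (within the scatter) in this assay. Among the compounds shown here, compound 4 therefore lies within the scatter of every earlier compound, and on this nitrogen only the step of a number 15 percentage points lower from compound 1 to compound 3 (beyond the scatter) still separates two compounds. No measurement at hand accounts for these numbers. Open, going by these compounds, is whether an amine or a carboxylic acid on this phenyl ring would move the number beyond the scatter. Also open, on these data alone, is how a morpholine in place of the phenyl ring would read.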